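A Larger Ring on a Compound at the Limit

The source may report more compounds than this note shows. Statements on the series, on what has been measured and on what is new or still open speak of the compounds shown alone.

Compound 1 `CS(=O)(=O)CCO/N=C/c1cc(C(=O)NOCCO)c(Nc2ccc(I)cc2F)c(F)c1F` gives 1.5 h in an in vitro ADME assay on microsomes from liver (Homo sapiens) for metabolic stability, tested at 1 uM; on this read-out lower numbers stand for a shorter-lived compound and higher numbers for a longer-lived compound. Compound 2 `CC(=O)NCCO/N=C/c1cc(C(=O)NOCCO)c(Nc2ccc(I)cc2F)c(F)c1F` gives > 6 h, which is a limit and not a number. Compound 3 `O=C(NOCCO)c1cc(CN2CCOC2=O)c(F)c(F)c1Nc1ccc(I)cc1F` gives > 6 h, which is also a limit. The picture so far is therefore incomplete, with the limit of > 6 h in this assay, at which 2 of the 3 values shown sit.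

Two measured steps are beyond the scatter. One is an at least 4.0-fold higher number from compound 1 to compound 2 (0.60 log units; beyond the scatter), and the other is an at least 4.0-fold higher number from compound 1 to compound 3 (0.60 log units; beyond the scatter). Both sizes are lower bounds, so the real gaps could be larger.

Compound 4 `O=C(NOCCO)c1cc(CN2OCCOC2=O)c(F)c(F)c1Nc1ccc(I)cc1F` keeps the shared core and changes only the ring, on a saturated chain carbon bound to an aromatic carbon: a group of 7 heavy atoms (3 carbon, 1 nitrogen, 3 oxygen; one six-membered non-aromatic ring with 3 hetero atoms) in place of a group of 6 heavy atoms (3 carbon, 1 nitrogen, 2 oxygen; one five-membered non-aromatic ring with 2 hetero atoms), on a saturated chain carbon bound to an aromatic carbon. The 2-oxo-1,3-oxazolidin-3-yl group leaves, and a six-membered non-aromatic ring with 3 hetero atoms enters.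

Among the measured compounds shown here, no measured step swaps one ring for another. For the measured compounds named here, the nearest guide is an at least 4.0-fold higher number from compound 1 to compound 3 (0.60 log units; beyond the scatter), which shows only that compound 3, the sole ring-bearing compound measured, outlasts compound 1. It says nothing firm about the size of a change within the ring, so no clear shift in either direction is expected. The expected step is a number no higher from compound 3 to compound 4 (the limit leaves the size open), which is not clearly beyond the scatter. In this assay, compound 4 is expected at 6 h, within an estimated range from 2.5 h to 14 h.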

Compound 4, half-life: 0.633 h
Compound 4: the middle estimate sits 9.5-fold (0.98 log units) above what was measured, outside the stated range (below it).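

Within this assay, the ring on the saturated chain carbon bound to an aromatic carbon proves to be a sensitive place: replacing 2-oxo-1,3-oxazolidin-3-yl with the six-membered non-aromatic ring with 3 hetero atoms gives an at least 9.4-fold lower number from compound 3 to compound 4 (0.97 log units; beyond the scatter). Among the compounds shown here, compound 3 was the only ring-bearing compound among the earlier ones, and compound 4 shows that a ring in this region does not by itself bring a long half-life, with an at least 9.4-fold lower number from compound 2 to compound 4 (0.97 log units; beyond the scatter) and a 2.4-fold lower number from compound 1 to compound 4 (0.37 log units; beyond the scatter), so it now also falls short of the compound with the methylsulfonyl chain. The first two of these steps give only minimum sizes, and the true gaps stay hidden: the limit of > 6 h in this assay, at which 2 of the 4 values shown sit.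

Compound 4 enlarges the ring and adds a ring oxygen in a single change, so the compounds shown cannot tell which of the two matters, or why the half-life falls. A 1,3-oxazinan-2-one ring, which has the larger ring size but not the added ring oxygen, would pull those two changes apart.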